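Quinolinone amine series: tolerance on canine kidney cells

The source may report more compounds than this note shows. Statements on the series, on what has been measured and on what is new or still open speak of the compounds shown alone.

Compound 1 `Cc1ccc2[nH]c(=O)c(CN(Cc3ccc(OCC(=O)OC(C)(C)C)cc3)Cc3ccc(C(C)(C)C)cc3)cc2c1` and compound 2 `CSc1ccc(CN(Cc2ccc(C(C)(C)C)cc2)Cc2cc3cc(C)ccc3[nH]c2=O)cc1` share one core and differ at one aromatic carbon, where compound 2 carries methylsulfanyl in place of (tert-butoxycarbonyl)methoxy. In a toxicity assay on MDCK cells (Canis lupus familiaris) for cytotoxicity, read by crystal violet staining, with a stated time of 48 h (a higher number here means that more compound is tolerated, a lower number that less compound is tolerated), compound 1 gives > 10000 nM, a limit of the assay. In this assay compound 2 gives > 5000 nM, again a limit and not a number. The step that the two limits leave unreadable from compound 1 to compound 2 therefore cannot be read, since both ends sit at limits, as shown by the limit of > 10000 nM in this assay, at which 1 of the 2 values shown sits, and (the limit of > 5000 nM in this assay, at which 1 of the 2 values shown sits). Compound 2 thus stands only as a limit, with no number to compare against.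

Compound 3 `Cc1ccc2[nH]c(=O)c(CN(Cc3ccc(SC(F)(F)F)cc3)Cc3ccc(C(C)(C)C)cc3)cc2c1` differs from compound 2 by trifluoromethyl in place of methyl on a sulfur. No measured step in this series changes a substituent on a sulfur, and the one measured step is unreadable, so nothing shown speaks to the size or direction of a change in this assay for this replacement. The expectation is that compound 3 stays near the limits seen so far, with a step that the limit leaves unreadable from compound 2 to compound 3 expected to lie within the scatter. Compound 3 is estimated at 8000 nM in this assay, with a range from 2000 nM to 30000 nM.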

Compound 3, half-maximal cytotoxic concentration: > 5000 nM
Compound 3 was reported as a limit; the forecaster's own chance of this, stated with the estimate: 60%; the middle value lies beyond the limit too.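

In this assay compound 3 gives > 5000 nM, a limit of the assay and not a number. The steps joining compound 3 to compound 1 and compound 2 therefore cannot be read: the limit of > 5000 nM in this assay, at which 2 of the 3 values shown sit.

Still open, as far as these compounds go, is the half-maximal cytotoxic concentration of compound 1, compound 2 and compound 3, and with it whether any of these replacements changes tolerance.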